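This account rests on a few compounds, and the source may have more. Where it says the series, first, only, none or still open, it means among the compounds named here.

Measured compounds and their values in a functional assay on HCT-116 cells (Homo sapiens) for antiproliferative activity, read by MTT assay, with a stated time of 48 h; on this read-out lower numbers stand for stronger inhibition and higher numbers for weaker inhibition:

Compound 1, `O=C(/C=C/c1cccc(NC(=O)c2ccccc2Br)c1)c1nc2ccccc2[nH]1`, gives 1680 nM.
Compound 2, `Cc1cccc(C(=O)Nc2cccc(/C=C/C(=O)c3nc4ccccc4[nH]3)c2)c1`, gives 1420 nM.
Compound 3, `O=C(Nc1cccc(/C=C/C(=O)c2nc3ccccc3[nH]2)c1)c1cc(Cl)cc(Cl)c1`, gives 1650 nM.

These three compounds share one core and differ only in the aryl group on the amide carbonyl. On the numbers shown, compound 3 stands second highest of the three, with compound 1 closest to it and compound 2 furthest; all three lie within the scatter of one another. The steps between them are small: a 1.2-fold lower number from compound 1 to compound 2 (0.07 log units; within the scatter), a 1.0-fold lower number from compound 1 to compound 3 (0.01 log units; within the scatter) and a 1.2-fold higher number from compound 2 to compound 3 (0.07 log units; within the scatter). Changing the aryl group on the carbonyl therefore left this assay essentially unmoved across the set.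

Compound 4, `O=C(/C=C/c1cccc(NS(=O)(=O)c2cccc(Cl)c2)c1)c1nc2ccccc2[nH]1`, is the next compound to be measured. It differs from compound 3 as follows: (3-chlorophenyl)sulfonyl in place of (3,5-dichlorophenyl)carbonyl on a nitrogen on an aromatic ring. For the measured compounds named here, none of the measured steps bears directly on the exchange of a carbonyl for a sulfonyl on this nitrogen; the three steps that do exist only vary the aryl group, and each was within the scatter. Going by these compounds, on that evidence the expected step is a 1.1-fold higher number from compound 3 to compound 4 (0.04 log units; within the scatter), with no direction beyond the scatter claimed, and the uncertainty is widened because the sulfonyl exchange itself is untested. Compound 4 is accordingly estimated at 1800 nM, with a range from 600 nM to 5500 nM.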

Compound 4, half-maximal inhibitory concentration: 737 nM
Compound 4: middle estimate off by 2.4-fold (0.39 log units), on the high side, within the range that was stated.
By their numbers in this assay, from the lowest: compounds 4, 2, 3 and 1 (each within the scatter of the next, the first and the last beyond it).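

In this assay, for the compounds shown here, the sulfonyl on this nitrogen produces the only steps in the set that clear the scatter, namely a 2.2-fold lower number from compound 3 to compound 4 (0.35 log units; beyond the scatter) and a 2.3-fold lower number from compound 1 to compound 4 (0.36 log units; beyond the scatter) and both are modest, while a 1.9-fold lower number from compound 2 to compound 4 (0.28 log units; within the scatter) stays inside it, so compound 2 goes against any claim that the sulfonyl compound stands apart from all three amides. The aryl exchanges on the carbonyl had left the read-out unmoved, so this position proves able to register a change once the carbonyl gives way to a sulfonyl, although in every one of these steps the aryl group changes along with it. Nothing measured here accounts for the difference.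

What the compounds shown leave open is how much belongs to the sulfonyl and how much to the aryl group, since no amide carrying 3-chlorophenyl and no sulfonyl carrying 3,5-dichlorophenyl appears among them. Also open, going by these compounds, is how this nitrogen would fare with a urea, or with a methylsulfonyl group in place of the arylsulfonyl group.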